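The compounds below may be only part of what the source reports. "The series", "measured", "known", "first", "only" and "open" are said of these compounds alone.

Compound 1 `CCCCCCNc1nc(-c2ccccc2)nc2c1nnn2Cc1ccccc1`, in an assay on Cerebral cortex for displacement of a labelled ligand from adenosine receptor A1 (Bos taurus); a higher number here means a weaker inhibitor, a lower number a stronger inhibitor: 13.2 nM
Compound 2 `CCCCCCNc1nc(-c2ccccc2)nc2c1nnn2Cc1ccccc1C(F)(F)F`, in this assay: "not determined" (no result reported)

Compound 2 therefore stands nowhere on a number scale: its result was not reported, so it offers no fixed point. Compound 3 `FC(F)(F)c1ccccc1Cn1nnc2c(NC3CCCC3)nc(-c3ccccc3)nc21` keeps the core of compound 2 and changes one group: cyclopentyl in place of hexyl on a nitrogen on an aromatic ring. No comparison between two measured compounds covers such a change, so the size of the step in this assay is open; with compound 1 and its 13.2 nM as the nearest measured relative, the expectation is a shift no larger than the usual scatter, in either direction. Compound 3 is thus expected to give about 10 nM in this assay, within a range from 3 nM to 40 nM.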

Compound 3, inhibition constant: 0.6 nM
For compound 3 the middle estimate is 17-fold (1.22 log units) above the measured one; the measured number lies below the stated range.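

For the compounds shown here, compound 2 has no reported number, so no step from compound 2 to compound 3 can be read. On these data alone, what the change from hexylamino to cyclopentylamino does on its own in this assay stays open. Nothing shown here explains the result.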